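The compounds below may be only part of what the source reports. "The series", "measured", "known", "first", "only" and "open" are said of these compounds alone.

Compound 1 `c1ccc(-c2cn3ccnc3c(-c3ccc4ncn(C5CCCCC5)c4c3)n2)cc1` and compound 2 `Brc1ccc(-c2cn3ccnc3c(-c3ccc4ncn(C5CCCCC5)c4c3)n2)cc1` share one core and differ only in the substituent on the pendant phenyl. In a physicochemical assay for lipophilicity, using the shake flask method, in phosphate buffer, measured as octanol-water partition, with a stated time of 85 min, at pH 7.4 (on this read-out higher numbers stand for higher lipophilicity and lower numbers for lower lipophilicity), compound 1 gives 1.74; in this assay compound 2 gives 1.73, and a number 0.01 log units lower from compound 1 to compound 2 (within the scatter). Of the two numbers, compound 2 holds the smaller one, with compound 1 nearest and within the scatter of it. Compound 3 `COc1ccccc1-c1cn2ccnc2c(-c2ccc3ncn(C4CCCCC4)c3c2)n1` follows from compound 2 by 2-methoxyphenyl in place of 4-bromophenyl on an aromatic carbon. For the measured compounds named here, only the step from compound 1 to compound 2 bears on this, and it stayed within the scatter; no measured step covers a methoxy group. The expected step is a number 0.13 log units lower from compound 2 to compound 3 (within the scatter), small and not beyond the scatter. Compound 3 is estimated at 1.6, between 1.2 and 2.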

Compound 3, partition coefficient: 1.72
Beside the measured number, compound 3's estimate is 0.12 log units below it; measured number inside the range.
By their numbers in this assay, from the lowest: compounds 3, 2 and 1 (each within the scatter of the next).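

In this assay, 2-methoxyphenyl in place of 4-bromophenyl gives a number 0.01 log units lower from compound 2 to compound 3 (within the scatter) and methoxy in place of hydrogen gives a number 0.02 log units lower from compound 1 to compound 3 (within the scatter), so a second substituent type on the pendant phenyl also stays within the scatter. With a hydrogen-bond acceptor now entering, the three compounds still lie within the scatter of one another, and no substituent shown on this phenyl separates from hydrogen. No supporting data offer an explanation for this. Going by these compounds, whether an amine or a carboxylic acid on this phenyl would give a step beyond the scatter remains open.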